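This account rests on a few compounds, and the source may have more. Where it says the series, first, only, none or still open, it means among the compounds named here.

Measured so far in an assay on Sf9 cells for inhibition of protein deacetylase HDAC6 (Homo sapiens), read by fluorescence, with a stated time of 40 min, tested at 100 nM; a lower number here means less inhibition, a higher number more inhibition at the concentration tested (going by the name of the read-out):
compound 1 `Cc1ccccc1-n1nc(-c2ccccc2)nc1CNc1ccc(C(=O)NO)cc1` gives 57.1%
compound 2 `CC(C)c1ccc(-n2nc(-c3ccccc3)nc2CNc2ccc(C(=O)NO)cc2)cc1` gives 52.6%

Compound 1 and compound 2 share the core and differ only in the aryl group on the aromatic nitrogen; the step of a number 4.5 percentage points lower from compound 1 to compound 2 (within the scatter) lies within the scatter, so the two numbers cannot be told apart. Compound 2 is thus neither separated from compound 1 nor anchored by any other measured point in this assay.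

Compound 3 `O=C(NO)c1ccc(NCc2nc(-c3ccccc3)nn2-c2ccc(Cl)cc2)cc1` is not yet measured. It differs from compound 2 by chloro in place of isopropyl on an aromatic carbon. Among the compounds with values here, the only measured step that touches the same region of the molecule is the exchange of the aryl group on the aromatic nitrogen, a number 4.5 percentage points lower from compound 1 to compound 2 (within the scatter), and that step stayed within the scatter. On this basis no step beyond the scatter is expected in this assay from compound 2 to compound 3; the expected step is a number 1.4 percentage points higher from compound 2 to compound 3 (within the scatter). Compound 3 is therefore estimated at 54%, with a range of 36% to 70%.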

Compound 3, a percentage reported as inhibition, at one concentration (the size of the read-out at that concentration, not a potency): 55.4%
Estimate against measurement, compound 3: 1.4 percentage points below, and the stated range covers the measured number.
By their numbers in this assay, from the lowest: compounds 2, 3 and 1 (each within the scatter of the next).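

In this assay, chloro in place of isopropyl on an aromatic carbon gives a number 2.8 percentage points higher from compound 2 to compound 3 (within the scatter) and shows that at this place, para to a large group, a change from a branched carbon group to a single halogen atom leaves the number level, without a step that can be read. Against the 2-methylphenyl group, the 4-chlorophenyl group gives a number 1.7 percentage points lower from compound 1 to compound 3 (within the scatter) and so all three aryl groups on the aromatic nitrogen remain indistinguishable at the single concentration tested. Nothing at hand bears on the reason for this flat result.

Going by these compounds, whether an amine or a carboxylic acid at this place would give a step beyond the scatter remains open. The compounds shown also share the rest of the core, so they say nothing about changes elsewhere in the molecule.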